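The compounds below may be only part of what the source reports. "The series", "measured", "known", "first", "only" and "open" are said of these compounds alone.

Series notes. The shared core carries a phenyl on a double-bonded chain carbon bound to a double-bonded chain carbon, and the three measured compounds vary only the substitution of that aryl group. Compound 1 `C=C(C/C(=C\c1ccccc1)C(=O)c1ccccc1)C(=O)c1ccccc1` gives 19000 nM in a functional assay on HeLa cells (Homo sapiens) for inhibition, read by sulforhodamine B assay, with a stated time of 48 h; a lower number here means a stronger inhibitor of growth, a higher number a weaker inhibitor of growth. Compound 2 `C=C(C/C(=C\c1ccc(F)cc1)C(=O)c1ccccc1)C(=O)c1ccccc1` gives 18000 nM in this assay, and compound 3 `C=C(C/C(=C\c1ccccc1F)C(=O)c1ccccc1)C(=O)c1ccccc1` gives 20000 nM. Compound 3 stands within the scatter of both neighbours: a 1.1-fold higher number from compound 1 to compound 3 (0.02 log units; within the scatter), and a 1.1-fold higher number from compound 2 to compound 3 (0.05 log units; within the scatter).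

The next member is compound 4 `C=C(C/C(=C\c1ccc(OC)cc1)C(=O)c1ccccc1)C(=O)c1ccccc1`. Relative to compound 3 the change is 4-methoxyphenyl in place of 2-fluorophenyl on a double-bonded chain carbon bound to a double-bonded chain carbon. Among the compounds with values here, the steps that bear on this are the three aryl substitution steps already in hand: a 1.1-fold lower number from compound 1 to compound 2 (0.02 log units; within the scatter), a 1.1-fold higher number from compound 1 to compound 3 (0.02 log units; within the scatter) and a 1.1-fold higher number from compound 2 to compound 3 (0.05 log units; within the scatter). None of them moved this assay beyond the scatter, so a fluoro on either position of the aryl group and the unsubstituted phenyl give indistinguishable numbers. Within the data shown here, a methoxy has not been measured, and the data give no step for an oxygen-bearing substituent on this aryl group.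

For compound 4 the step expected in this assay is therefore a 1.1-fold lower number from compound 3 to compound 4 (0.05 log units; within the scatter), with no change beyond the scatter anticipated. The estimate for compound 4 in this assay is 18000 nM, with a range from 8000 nM to 40000 nM.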

Compound 4, concentration for 50% growth inhibition: 320 nM
For compound 4 the middle estimate is 56-fold (1.75 log units) above the measured one; the whole stated range lies above it.
By their numbers in this assay, from the lowest: compound 4; then compounds 2, 1 and 3 (each within the scatter of the next).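

At this position, on a double-bonded chain carbon bound to a double-bonded chain carbon, the aryl group is not neutral in this assay: adding a methoxy to the unsubstituted phenyl gives a 59-fold lower number from compound 1 to compound 4 (1.77 log units; beyond the scatter), and methoxy in place of fluoro gives a 56-fold lower number from compound 2 to compound 4 (1.75 log units; beyond the scatter). The exchange of 2-fluorophenyl for 4-methoxyphenyl gives a 63-fold lower number from compound 3 to compound 4 (1.80 log units; beyond the scatter), so all three routes to compound 4 are large steps beyond the scatter, whereas the fluoro changes among compounds 1, 2 and 3 all stayed within it. Nothing available explains why this one aryl group separates from the other three.

Among the compounds shown, methoxy appears only as 4-methoxyphenyl, so it remains open whether the step depends on where the methoxy sits on the aryl group. From the compounds shown here alone, it also remains open whether the step is specific to methoxy or is shared by a hydroxy, an ethoxy or an amine on this aryl group, and whether it carries over to changes in the two phenyl ketone groups of the shared core.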